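Amide nitrogen substituent: pyrazolyl to cyclohexyl

A few compounds are considered here, and "the series" means these few. Any claim that something is new, unique, unknown or untested is made for them only; others in the source may bear on it.

Of the compounds shown here, two have been measured in an assay on HEK293 cells for agonist activity at transient receptor potential cation channel subfamily M member 8 (Homo sapiens), read by fluorescence and calcium flux, with a stated time of 15 min; on this read-out higher numbers stand for an effect only at larger amounts of compound and lower numbers for an effect already at smaller amounts. Compound 1 `CCN(Cc1cccs1)C(=O)c1cc2cc(C)ccc2o1` gives 120 nM in this assay. Compound 2 `Cc1ccc(OCC(=O)N(Cc2cccs2)c2c[nH]nc2C)cc1` gives 0.4 nM in this assay. For the measured compounds named here, compound 2 therefore stands lowest of the two numbers; its only neighbour, compound 1, lies far higher, well beyond the scatter of repeated measurements.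

Compound 3 `Cc1ccc(OCC(=O)N(Cc2cccs2)C2CCCCC2)cc1` has not yet been measured. It differs from compound 2 in one place: cyclohexyl in place of 3-methyl-1H-pyrazol-4-yl on an amide-type nitrogen. Going by the values given here, no pair of measured compounds isolates this change; compound 1 and compound 2 differ from each other in more than one place, so their two values show only that the series already spans a wide window in this assay.

For compound 3 the expectation is a step upward from compound 2 in this assay, estimated as a 50-fold higher number from compound 2 to compound 3 (1.70 log units; beyond the scatter), which would lie beyond the scatter. The estimate for compound 3 in this assay is 20 nM, expected to fall between 2 nM and 200 nM; with a single measured pair as background, the range is kept wide.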

Compound 3, half-maximal effective concentration: 40000 nM
Compound 3: the middle estimate sits 2000-fold (3.30 log units) below what was measured, outside the stated range (above it).
By their numbers in this assay, from the lowest: compound 2; then compound 1; then compound 3.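

In this assay, replacing 3-methyl-1H-pyrazol-4-yl with cyclohexyl on the amide-type nitrogen gives a 100000-fold higher number from compound 2 to compound 3 (5.00 log units; beyond the scatter), the only step shown that isolates this position, and it shows that the read-out depends strongly on the group held there. The two groups have the same heavy-atom count, so the step does not follow from a difference in that count; it does, however, combine several printed differences: aromatic five-membered ring against non-aromatic six-membered ring, nitrogen against carbon only, and the hydrogen-bond donor and acceptor of the leaving group against none in the entering one. No measurement shown separates these differences or bears on the origin of the step, so its cause remains unassigned.

Still open, on these data alone, is which feature of the 3-methyl-1H-pyrazol-4-yl group matters, a question that phenyl, 1H-pyrazol-4-yl without the methyl, or piperidin-4-yl on the same nitrogen would help to answer. Also open, as far as these compounds go, is how the series responds to an open-chain substituent such as ethyl or a longer alkyl chain on this nitrogen with the rest of compound 2 held constant.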